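Methoxy in place of acetyl on the pyrimidine ring

A few compounds are considered here, and "the series" means these few. Any claim that something is new, unique, unknown or untested is made for them only; others in the source may bear on it.

Measured compounds:
- compound 1 `CC(C)(C)OC(=O)N1CCC(c2coc3c(N4CCCc5cc(S(C)(=O)=O)ccc54)ncnc23)CC1`: 793 nM
- compound 2 `CC(=O)c1cnc(N2CCC(c3coc4c(N5CCc6cc(S(C)(=O)=O)ccc65)ncnc34)CC2)nc1`: 78 nM
- compound 3 `CC(C)(C)OC(=O)N1CCC(c2c[nH]c3c(Nc4ccc(S(C)(=O)=O)cc4F)ncnc23)CC1`: > 1000 nM

Of the compounds shown here, three sharing the same core have been tested in a functional assay on cells for agonist activity at Glucose-dependent insulinotropic receptor (Homo sapiens), read by a luciferase reporter, with a stated time of 4 h; on this read-out higher numbers stand for an effect only at larger amounts of compound and lower numbers for an effect already at smaller amounts. Compound 2 gives 78 nM, the lowest of the two numbers reported; compound 1 gives 793 nM, a higher number, and the gap between the two lies beyond the usual scatter. For compound 3 this assay reports only a limit, > 1000 nM, rather than a number (the limit of > 1000 nM in this assay, at which 1 of the 3 values shown sits).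

The unmeasured compound 4 `COc1cnc(N2CCC(c3coc4c(N5CCc6cc(S(C)(=O)=O)ccc65)ncnc34)CC2)nc1` differs from compound 2 in one place: methoxy in place of acetyl on an aromatic carbon. For the measured compounds named here, no pair of measured compounds differing in a single place is available, so the size of this step cannot be read from the data. Since compound 2 gives 78 nM, a moderate weakening in this assay is expected for compound 4, meaning an estimated step of a 2.6-fold higher number from compound 2 to compound 4 (0.41 log units; beyond the scatter). Compound 4 is therefore expected to give about 200 nM, with a range from 70 nM to 600 nM.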

Compound 4, half-maximal effective concentration: 310 nM
Estimate against measurement, compound 4: 1.6-fold (0.19 log units) below; measured number inside the range.
By their numbers in this assay, from the lowest: compound 2; then compound 4; then compound 1. At a limit, above all of these: compound 3.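

In this assay, for the compounds shown here, exchanging 5-acetylpyrimidin-2-yl for 5-methoxypyrimidin-2-yl gives a 4.0-fold higher number from compound 2 to compound 4 (0.60 log units; beyond the scatter), the first single change whose size can be read. It shows that this position on the pyrimidine responds to the group it carries, while the change still leaves compound 4 with a measured number, 310 nM, rather than a limit. Nothing measured here accounts for the step.

The compounds shown leave open how a nitrile, an amide or a plain hydrogen on this aromatic carbon would read, and so whether the carbonyl of the acetyl is what separates compound 2 from compound 4. They also leave open whether the same exchange would give a step of this size on a different core.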